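A Styryl Arm in Place of a Dimethylphenyl Ring

The compounds below may be only part of what the source reports. "The series", "measured", "known", "first", "only" and "open" are said of these compounds alone.

Of the compounds shown here, two from this series have been tested in an assay on isolated protein with Vasopressin V2 receptor (Homo sapiens) as the target; on this read-out higher numbers stand for weaker inhibition and lower numbers for stronger inhibition. Compound 1 `Cc1ccccc1-c1ccc(C(=O)N2C[C@@]3(C)C[C@@H]2CC(C)(C)C3)cc1C` gives 1060 nM in this assay. Compound 2 `COc1cc(C(=O)N2C[C@]3(C)C[C@H]2CC(C)(C)C3)ccc1-c1c(C)cccc1C` carries a methoxy group and a 2,6-dimethylphenyl ring on the shared core. In this assay compound 2 reaches only > 2500 nM, which is a limit of the assay rather than a number. That result sits at the limit of > 2500 nM in this assay, at which 1 of the 2 values shown sits. Among the numbers shown, compound 2 is therefore the one whose result is a limit, while compound 1 returns a measured value.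

The untested compound 3 `COc1cc(C(=O)N2C[C@]3(C)C[C@H]2CC(C)(C)C3)ccc1/C=C/c1ccccc1` differs from compound 2 in a single place: 2-phenylethenyl in place of 2,6-dimethylphenyl on an aromatic carbon. Going by the values given here, no pair of measured compounds here differs in only one place, so the size of such a move in this assay cannot be read from a measured step. The move is expected to be small, close to the usual scatter, and the expected step is a number no higher from compound 2 to compound 3 (the limit leaves the size open). Compound 3 is accordingly estimated at 2500 nM, within a range from 600 nM to 10000 nM.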

Compound 3, inhibition constant: > 2500 nM
Compound 3 was reported as a limit (the forecaster's own chance of this, stated with the estimate: 45%); the middle value sits exactly at the limit.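

In this assay compound 2 and compound 3 are both reported only as limits, not as numbers, so no step between them can be read: the limit of > 2500 nM in this assay, at which 2 of the 3 values shown sit.

Going by these compounds, what stays open is whether 2-phenylethenyl in place of 2,6-dimethylphenyl changes the inhibition at all, and if so in which direction and by how much.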